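A few compounds are considered here, and "the series" means these few. Any claim that something is new, unique, unknown or untested is made for them only; others in the source may bear on it.

Two compounds of this series have readings in a functional assay on DU-145 cells (Homo sapiens) for antiproliferative activity, read by MTT assay, with a stated time of 48 h (a higher number here means a weaker inhibitor, a lower number a stronger inhibitor), and only one of them is an actual number. Compound 2 `C#CCOC(=O)/C(C)=C/CC/C(C)=C/CC/C(C)=C/CC[C@@H]1[C@@]2(C)CCC(=O)C(C)(C)[C@H]2CC[C@@]1(C)O` carries a small propargyl ester on its side chain, and in this assay compound 2 gives 46100 nM. Compound 1 `C/C(=C\CC/C(C)=C/CC[C@@H]1[C@@]2(C)CCC(=O)C(C)(C)[C@H]2CC[C@@]1(C)O)CC/C=C(\C)C(=O)OCc1cn(-c2ccccc2[N+](=O)[O-])nn1` carries a much larger ester group built on a triazole ring. For compound 1 this assay reports no number, only a limit of > 150000 nM. So one of the two values shown sits at the upper boundary of what the assay can report (the limit of > 150000 nM in this assay, at which 1 of the 2 values shown sits), and compound 2, with the single real number, is the only point of comparison.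

Compound 3 `C/C(=C\CC/C(C)=C/CC[C@@H]1[C@@]2(C)CCC(=O)C(C)(C)[C@H]2CC[C@@]1(C)O)CC/C=C(\C)C(=O)OCc1cn(-c2ccc(Cl)cc2)nn1` keeps the whole core and side chain of compound 2 and differs from it only at the ester end: 1-(4-chlorophenyl)-1H-1,2,3-triazol-4-yl in place of ethynyl on a saturated chain carbon bound to an oxygen next to a carbonyl group. For the measured compounds named here, no measured pair in the set shows exactly this kind of step. The step from compound 2 to compound 3 is expected to weaken inhibition by a 2.6-fold higher number from compound 2 to compound 3 (0.42 log units; beyond the scatter), beyond the ordinary scatter, since compound 1 with its own triazole ester reaches only the limit > 150000 nM. The expected value for compound 3 is therefore 120000 nM, within a range from 45000 nM to 300000 nM, with a real chance that only a limit is reported.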

Compound 3, half-maximal inhibitory concentration: > 150000 nM
Compound 3 ended at the assay's limit (the forecaster's own chance of this, stated with the estimate: 55%); middle value at least 1.2-fold (0.09 log units) from the limit.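

In this assay compound 3 gives > 150000 nM, which is a limit of the assay and not a number. For the compounds shown here, this is the first readable one-place step: on a saturated chain carbon bound to an oxygen next to a carbonyl group, 1-(4-chlorophenyl)-1H-1,2,3-triazol-4-yl in place of ethynyl gives an at least 3.2-fold higher number from compound 2 to compound 3 (0.51 log units; beyond the scatter), and with a limit at one end the true size may be greater. The step between the two triazole esters cannot be read, so 4-chlorophenyl and 2-nitrophenyl cannot be ranked, and all that can be said is that neither gives a number: the limit of > 150000 nM in this assay, at which 2 of the 3 values shown sit.

The compounds shown leave open whether any triazole ester can give a real reading in this assay, for instance one with a plain phenyl or a 4-aminophenyl on the aromatic nitrogen. They also leave open how much of the loss belongs to the triazole ring and how much to the aromatic group on it, a question that a simple methyl ester or benzyl ester at this place would help to answer.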